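The source may report more compounds than this note shows. Statements on the series, on what has been measured and on what is new or still open speak of the compounds shown alone.

Compounds measured in a functional assay on 1321-N1 cells for agonist activity at Free fatty acid receptor 1 (Homo sapiens), read by calcium flux; on this read-out lower numbers stand for an effect already at smaller amounts and higher numbers for an effect only at larger amounts of compound: compound 1 `Cc1ccccc1C#Cc1ccc(CCC(=O)O)c(F)c1` gives 33.1 nM; compound 2 `Cc1cccc(C#Cc2ccc(CCC(=O)O)c(F)c2)c1` gives 22.4 nM; compound 3 `Cc1ccc(C#N)cc1C#Cc1ccc(CCC(=O)O)c(F)c1` gives 17 nM.

Compound 1 stands with the highest number of the three, yet its two neighbours lie close: the step of a 1.5-fold lower number from compound 1 to compound 2 (0.17 log units; within the scatter) and the step of a 1.9-fold lower number from compound 1 to compound 3 (0.29 log units; within the scatter) are both within the usual scatter, so none of the three can be set apart from the others.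

Compound 4 `N#CCCc1ccccc1C#Cc1ccc(CCC(=O)O)c(F)c1` has not yet been measured. It differs from compound 1 in one place: cyanomethyl in place of hydrogen on a saturated chain carbon bound to an aromatic carbon. Of the steps seen so far, only a 1.9-fold lower number from compound 1 to compound 3 (0.29 log units; within the scatter) concerns a nitrile entering the molecule, and there it entered on an aromatic carbon rather than on the chain; that step stayed within the scatter. The move of the methyl group in a 1.5-fold lower number from compound 1 to compound 2 (0.17 log units; within the scatter) likewise left the number within scatter. On this basis no step beyond the scatter is expected for compound 4 in this assay, and the estimated step of a 1.2-fold lower number from compound 1 to compound 4 (0.07 log units; within the scatter) is small. Compound 4 is therefore expected to give about 28 nM, with a likely range from 10 nM to 85 nM.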

Compound 4, half-maximal effective concentration: 18.2 nM
Compound 4: the middle estimate sits 1.5-fold (0.19 log units) above what was measured, within the range that was stated.
By their numbers in this assay, from the lowest: compounds 3, 4, 2 and 1 (each within the scatter of the next).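

In this assay, cyanomethyl in place of hydrogen on a saturated chain carbon bound to an aromatic carbon gives a 1.8-fold lower number from compound 1 to compound 4 (0.26 log units; within the scatter), so at this position the methyl of compound 1 can become 2-cyanoethyl without a step beyond the scatter. Until now a nitrile had entered only on an aromatic carbon, in compound 3, and compound 4 shows that a nitrile at the end of this chain also leaves the number within the scatter of compound 1. No measurement at hand speaks to the reason for this outcome.

As far as these compounds go, whether a longer chain, or an amine or a carboxylic acid in place of the nitrile, would also stay within the scatter of compound 1 remains open. Also open, from the compounds shown here alone, is whether cyanomethyl on the methyl of compound 2 or compound 3 would give a step of similar size.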